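From Bromo to Fluoro on a Shared Core

The source may report more compounds than this note shows. Statements on the series, on what has been measured and on what is new or still open speak of the compounds shown alone.

Compound 1 `COc1ccc(Nc2cc(C)nc(SCc3nc4ccccc4[nH]3)n2)cc1` gives 67400 nM in a functional assay on PC-3 cells (Homo sapiens) for cytotoxicity, read by MTT assay, with a stated time of 72 h; on this read-out higher numbers stand for weaker inhibition and lower numbers for stronger inhibition.
Compound 2 `Cc1cc(Nc2ccc(Cl)cc2)nc(SCc2nc3ccccc3[nH]2)n1` gives 36000 nM in this assay.
Compound 3 `Cc1cc(Nc2ccc(Br)cc2)nc(SCc2nc3ccccc3[nH]2)n1` gives 37100 nM in this assay.

Compound 3 stands second highest of the three numbers. Its nearest neighbour is compound 2, with a 1.0-fold higher number from compound 2 to compound 3 (0.01 log units; within the scatter); compound 1 is furthest off, with a 1.8-fold lower number from compound 1 to compound 3 (0.26 log units; within the scatter).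

Compound 4 `Cc1cc(Nc2ccc(F)cc2)nc(SCc2nc3ccccc3[nH]2)n1` differs from compound 3 by fluoro in place of bromo on an aromatic carbon. For the measured compounds named here, only one measured step exchanges one halogen for another, a 1.0-fold higher number from compound 2 to compound 3 (0.01 log units; within the scatter), and it lies within the scatter. The steps of a 1.9-fold lower number from compound 1 to compound 2 (0.27 log units; within the scatter) and a 1.8-fold lower number from compound 1 to compound 3 (0.26 log units; within the scatter) replace methoxy with a halogen and are also within the scatter. Going by the values given here, no step among the three measured compounds exceeds the scatter, so no step beyond it is expected in this assay for compound 4. Compound 4 is therefore estimated at 45000 nM, within 20000 nM to 100000 nM, an expected step of a 1.2-fold higher number from compound 3 to compound 4 (0.08 log units; within the scatter).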

Compound 4, half-maximal inhibitory concentration: 56200 nM
Beside the measured number, compound 4's estimate is 1.2-fold (0.10 log units) below it; the measured number falls inside the stated range.
By their numbers in this assay, from the lowest: compounds 2, 3, 4 and 1 (each within the scatter of the next).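

Fluoro at this place stays within the scatter of every other group in this assay: a 1.5-fold higher number from compound 3 to compound 4 (0.18 log units; within the scatter), a 1.6-fold higher number from compound 2 to compound 4 (0.19 log units; within the scatter) and a 1.2-fold lower number from compound 1 to compound 4 (0.08 log units; within the scatter). Methoxy, chloro, bromo and fluoro on this aromatic carbon therefore cannot be told apart in this assay, and the exchange of halogens now covers all three without a step beyond the scatter. Nothing offered here explains these numbers. On these data alone, it remains open whether an amine, a carboxylic acid or a nitrile at this place would give a step beyond the scatter.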